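Benzyl ether to allyl ether in compound 4

A few compounds are considered here, and "the series" means these few. Any claim that something is new, unique, unknown or untested is made for them only; others in the source may bear on it.

In a functional assay on THP-1 cells (Homo sapiens) for inhibition, read by sulforhodamine B assay, with a stated time of 48 h (a higher number here means a weaker inhibitor, a lower number a stronger inhibitor), compound 1 `CCOC(=O)C(C)C(O)(c1ccc(OC)c(OC)c1OC)c1cccc2ccccc12` is reported only as a limit of the assay, > 20000 nM. Compound 3 `COc1ccc(C(O)(Cc2ccccc2)c2cccc3ccccc23)c(OC)c1OC` gives a number in this assay, 12400 nM. The single measured step among these compounds, an at least 1.6-fold lower number from compound 1 to compound 3 (0.20 log units; that floor lies within the scatter), runs from that limit to a number, and the limit of > 20000 nM in this assay, at which 2 of the 3 values shown sit, is the ceiling at which compound 1 sits. Compound 2 `COc1ccc(C(OCc2ccccc2)c2cccc3ccccc23)c(OC)c1OC` likewise stands only at a limit in this assay, > 20000 nM. It therefore shares the ceiling of the assay and shows no number of its own.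

Compound 4 `C=CCOC(c1ccc(OC)c(OC)c1OC)c1cccc2ccccc12` differs from compound 2 in one place: vinyl in place of phenyl on a saturated chain carbon bound to an oxygen on a saturated carbon. Going by the values given here, no measured step touches this ether position; the step from compound 1 to compound 3 alters the other side of the same saturated carbon and its floor lies within the scatter. With compound 2 at a limit and nothing bearing directly on the change, compound 4 is expected to move by about a step that the limit leaves unreadable from compound 2 to compound 4 in this assay, that is, nothing beyond the scatter. The estimate for compound 4 in this assay is 25000 nM, with a range from 10000 nM to 60000 nM, and a good chance that only the limit is reported again.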

Compound 4, half-maximal inhibitory concentration: > 20000 nM
Compound 4 was reported as a limit; the forecaster's own chance of this, stated with the estimate: 70%; the middle value does not contradict the limit.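

In this assay compound 4 is reported only as a limit (> 20000 nM). Compound 2 also stands only at a limit, so no step can be read from compound 2 to compound 4: (the limit of > 20000 nM in this assay, at which 3 of the 4 values shown sit). The compounds shown leave open whether allyloxy in place of benzyloxy changes the inhibition at all, and what number either compound would give.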